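Swapping chloro for bromo in two oxime series

This account rests on a few compounds, and the source may have more. Where it says the series, first, only, none or still open, it means among the compounds named here.

Compound 1 `O/N=C(\C=C\c1cccs1)c1ccc(Cl)cc1` was tested in an ADME assay on cells (Mus musculus, strain Balb/c) for cytotoxicity, read by MTT assay, with a stated time of 48 h (on this read-out lower numbers stand for higher toxicity in this test and higher numbers for lower toxicity in this test), and gives 11800 nM. Compound 2 `O/N=C(\C=C\c1ccc(F)cc1)c1ccc(Cl)cc1` has a core that differs from that of compound 1 in a way that is not broken down here. In the same test compound 2 gives 11500 nM. Compound 3 `O/N=C(\C=C\c1ccc(F)cc1)c1ccc(Br)cc1` carries one change relative to compound 2, namely (bromo in place of chloro on an aromatic carbon). Compound 3 gives 20300 nM; the step between these two is a 1.8-fold higher number from compound 2 to compound 3 (0.25 log units; within the scatter).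

Compound 4 `O/N=C(\C=C\c1cccs1)c1ccc(Br)cc1` has not yet been measured. It differs from compound 1 by bromo in place of chloro on an aromatic carbon, and since the place of the change is described in the same words as for the pair of compound 2 and compound 3, this is the same change applied to another core.

The expected step from compound 1 to compound 4 is a 1.6-fold higher number from compound 1 to compound 4 (0.21 log units; within the scatter), which rests on the earlier step of a 1.8-fold higher number from compound 2 to compound 3 (0.25 log units; within the scatter) between compound 2 and compound 3. On that basis the estimate for compound 4 is 19000 nM, expected to fall between 10000 nM and 38000 nM.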

Compound 4, half-maximal cytotoxic concentration: 15400 nM
The estimate for compound 4 lay 1.2-fold (0.09 log units) above the measured number; low and high end bracket the measured number.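

In this assay, bromo in place of chloro on the aromatic carbon of the core of compound 1 gives a 1.3-fold higher number from compound 1 to compound 4 (0.12 log units; within the scatter) on this core. This step is within the usual scatter of repeated measurements, so it does not show that the swap really moves the number on this core, and two cores are too few to make a rule for the whole series. What can be said is narrower: the swap behaves alike on both cores, with no difference between them that this test can detect: the same change on two cores in this assay, a 1.8-fold higher number (0.25 log units; within the scatter) from compound 2 to compound 3 and a 1.3-fold higher number (0.12 log units; within the scatter) from compound 1 to compound 4, 1.4-fold (0.13 log units) apart, within the scatter of two such steps

The compounds shown leave open whether the same agreement would hold for other groups at that place on the six-membered ring, such as a methyl group, an amine or a carboxylic acid, whose steps might be large enough to stand clear of the scatter. They also leave open whether the swap from chloro to bromo would behave the same way on a core different from these two.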